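The source may report more compounds than this note shows. Statements on the series, on what has been measured and on what is new or still open speak of the compounds shown alone.

Of the compounds shown here, three have been measured so far in a functional assay (aorta) with Rattus norvegicus as the target (on this read-out higher numbers stand for weaker inhibition and lower numbers for stronger inhibition), and their numbers spread widely. Compound 1 (`CC1(C)Oc2ccc(C#N)cc2[C@@H](/N=C(\NC#N)NCc2ccccc2)[C@@H]1O`) gives 2400 nM there, the second highest of the three numbers. Compound 3 (`CC1(C)Oc2ccc(C#N)cc2[C@@H](NC(=O)Nc2cccnc2)[C@@H]1O`) stands lower at 500 nM and compound 2 (`CCC(C)(C)/N=C(\NC#N)N[C@@H]1c2cc(C#N)ccc2OC(C)(C)[C@H]1O`) stands higher at 29800 nM with both gaps to compound 1 lying beyond the usual scatter. Neither of these two differs from compound 1 in only one place, so their gaps cannot be tied to any single group.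

Compound 4 (`CC(=O)c1cccc(N/C(=N/[C@@H]2c3cc(C#N)ccc3OC(C)(C)[C@H]2O)NC#N)c1`) has not yet been measured. It keeps the core of compound 1 and changes one group, with 3-acetylphenyl in place of benzyl on an amine nitrogen. The entering group still holds a six-membered aromatic ring of carbon only, now joined directly to that nitrogen.

Within the data shown here, no measured step shows what such a swap does, so the expectation is a cautious one: a slight move to a lower number, but nothing beyond the scatter, taking compound 1 at 2400 nM as the closest reference. The estimated change is a 1.6-fold lower number from compound 1 to compound 4 (0.20 log units; within the scatter) and it is expected to stay within the scatter. For compound 4 the expected value is 1500 nM with an estimated range from 350 nM to 7000 nM around it.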

Compound 4, half-maximal inhibitory concentration: 8400 nM
Compound 4: the middle estimate sits 5.6-fold (0.75 log units) below what was measured; the measured number lies above the stated range.
By their numbers in this assay, from the lowest: compound 3; then compound 1; then compound 4; then compound 2.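

In this assay, the swap of benzyl for 3-acetylphenyl on the amine nitrogen gives a 3.5-fold higher number from compound 1 to compound 4 (0.54 log units; beyond the scatter). Among these compounds, this is the first step here in which only one group changes, and it shows that the number responds to what is attached at this nitrogen. Keeping a six-membered aromatic ring of carbon only was not enough to hold the number within the scatter of compound 1, although the ring is now joined directly to the nitrogen and the entering group also carries an acetyl group. Nothing measured here explains why the number rose.

Among the compounds shown here, the single step changes both of these features at once, so it leaves open which one accounts for the rise; a plain phenyl group or a 3-acetylbenzyl group on the same nitrogen would separate the two. Going by these compounds, it also remains open whether a phenyl ring carrying a methoxy group instead of the acetyl group would move the number in the same direction.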